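The compounds below may be only part of what the source reports. "The series", "measured", "known", "first", "only" and "open" are said of these compounds alone.

Compound 1 `C/C(=N/NC(=S)Nc1ccc([N+](=O)[O-])cc1)c1ccccn1`: 160 nM
Compound 2 `CC(=NNC(=S)Nc1ccc(I)cc1)c1ccccn1`: 59 nM

In a functional assay on U-87MG ATCC cells (Homo sapiens) for cytotoxicity, read by MTT assay, with a stated time of 48 h (on this read-out higher numbers stand for weaker inhibition and lower numbers for stronger inhibition), compound 2 has the lower of the two numbers, and its gap to compound 1 lies beyond the usual scatter. Compound 3 `CC(=NNC(=S)Nc1ccc([N+](=O)[O-])cc1)c1ccccn1` differs from compound 2 by one change, nitro in place of iodo on an aromatic carbon. Within the data shown here, no measured pair shows this change alone. However, compound 1 at 160 nM also carries the nitro group, and its drawing differs from compound 3 only in specifying the geometry of one double bond. A rise in the number beyond the scatter, meaning weaker inhibition, is therefore expected. The expected change is a 2.5-fold higher number from compound 2 to compound 3 (0.41 log units; beyond the scatter). The estimated value for compound 3 is 150 nM, with an expected range of 75 nM to 300 nM.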

Compound 3, half-maximal inhibitory concentration: 160 nM
For compound 3 the middle estimate is 1.1-fold (0.03 log units) below the measured one; the range from low to high includes it.
By their numbers in this assay, from the lowest: compound 2; then compounds 1 and 3 (each within the scatter of the next).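

Nitro in place of iodo can now be read alone in this assay: the swap gives a 2.7-fold higher number from compound 2 to compound 3 (0.43 log units; beyond the scatter), which means weaker inhibition. Leaving the double-bond geometry undrawn shows no change at the digits printed from compound 1 to compound 3 (within the scatter), so the nitro result holds for both drawings. This second comparison rests on a difference in drawing alone: the fact that one of compounds 1 and 3 is drawn with a defined configuration and the other without, at the place where they differ.

From the compounds shown here alone, only iodo and nitro can be compared at this place, so it remains open how an amine or a carboxylic acid there would behave. Going by these compounds, it also remains open whether the undrawn double bond of compound 3 has the same geometry as in compound 1.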